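A few compounds are considered here, and "the series" means these few. Any claim that something is new, unique, unknown or untested is made for them only; others in the source may bear on it.

Measured compounds in a functional assay on HCT-116 cells (Homo sapiens) for antiproliferative activity, read by MTT assay, with a stated time of 24 h; on this read-out higher numbers stand for weaker inhibition and lower numbers for stronger inhibition:
compound 1 `CCN(CC)c1ccc(/C=C/C(=O)c2ccc(OC)c3c2OC(C)(C)C=C3)cc1`: 620 nM
compound 2 `COc1ccc(C(=O)/C=C/c2ccc(-n3ccnc3)cc2)c2c1C=CC(C)(C)O2`: > 10000 nM

In this assay compound 1 gives 620 nM. For compound 2 this assay returns > 10000 nM, which is a limit of the assay and not a number. Between the two stands an at least 16-fold higher number from compound 1 to compound 2 (1.20 log units; beyond the scatter). From the compounds shown here alone, compound 2 therefore sits at the weak end of the pair, at the limit of > 10000 nM in this assay, at which 1 of the 2 values shown sits, and its true number is unknown.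

Compound 3 `COc1ccc(C(=O)/C=C/c2ccc([N+](=O)[O-])cc2)c2c1C=CC(C)(C)O2` is not yet measured in this assay. It differs from compound 2 by nitro in place of 1H-imidazol-1-yl on an aromatic carbon. For the measured compounds named here, only one measured step exists, and it concerns the exchange of diethylamino, not of nitro; it bears on the new step only in showing that the group on this aromatic carbon can shift the number a long way. With compound 2 known only as a limit, the step to compound 3 can be read only if compound 3 comes down into the measurable range. The expectation is that compound 3 remains weak. Compound 3 is estimated at 8000 nM, with a range from 2000 nM to 30000 nM. The expected step is an at least 1.2-fold lower number from compound 2 to compound 3 (0.09 log units; that floor lies within the scatter), with a considerable chance that again only a limit is reported.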

Compound 3, half-maximal inhibitory concentration: 8880 nM
Beside the measured number, compound 3's estimate is 1.1-fold (0.05 log units) below it; low and high end bracket the measured number.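

In this assay compound 3 gives 8880 nM, so nitro on this aromatic carbon returns a measurable value in the same weak region as the earlier exchange. For the compounds shown here, compound 2 gives > 10000 nM, which is a limit of the assay, and the series holds only this one such value: the limit of > 10000 nM in this assay, at which 1 of the 3 values shown sits. The step of an at least 1.1-fold lower number from compound 2 to compound 3 (0.05 log units; that floor lies within the scatter) therefore sets no order between nitro and 1H-imidazol-1-yl, whereas a 14-fold higher number from compound 1 to compound 3 (1.16 log units; beyond the scatter) gives a second large step away from diethylamino, alongside an at least 16-fold higher number from compound 1 to compound 2 (1.20 log units; beyond the scatter), so both replacements at this position, para to a large group, leave the number far higher than with diethylamino.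

Going by these compounds alone, with only three compounds, and compound 2 known only as a limit, the size of the nitro to 1H-imidazol-1-yl step remains unknown. Also open, from the compounds shown here alone, is whether another amine on this aromatic carbon, such as dimethylamino or piperidine, would stay near compound 1 or whether a methoxy group there would fall with compound 2 and compound 3, so the link between the diethylamino group and the lower number rests on these two exchanges alone.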